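Microsomal half-life: chlorostyryl arm replaces the triazolylmethyl arm

This account rests on a few compounds, and the source may have more. Where it says the series, first, only, none or still open, it means among the compounds named here.

Compound 1 `CC(C)(O)c1cn(Cc2nnc(-c3cc(S(N)(=O)=O)c(SCc4ccccc4)cc3Cl)o2)nn1` gives 0.23 h in an ADME assay on microsomes from liver (Homo sapiens) for metabolic stability, read by LC-MS, using NADPH, tested at 5 uM; on this read-out higher numbers stand for a longer-lived compound and lower numbers for a shorter-lived compound; compound 2 `COc1ccc(-c2cn(Cc3nnc(-c4cc(S(N)(=O)=O)c(SCc5ccccc5)cc4Cl)o3)nn2)cc1` gives 0.215 h in this assay, and the step of a 1.1-fold lower number from compound 1 to compound 2 (0.03 log units; within the scatter) stays within the scatter, so the two numbers cannot be told apart. Compound 3 `NS(=O)(=O)c1cc(-c2nnc(/C=C/c3cccc(Cl)c3)o2)c(Cl)cc1SCc1ccccc1` is not yet measured. It differs from compound 1 in one place: 2-(3-chlorophenyl)ethenyl in place of (4-(1-hydroxy-1-methylethyl)-1H-1,2,3-triazol-1-yl)methyl on an aromatic carbon. Among the measured compounds shown here, the only measured step, a 1.1-fold lower number from compound 1 to compound 2 (0.03 log units; within the scatter), swaps 1-hydroxy-1-methylethyl for 4-methoxyphenyl and leaves the rest of compound 1 intact; it does not bear directly on removing the whole triazolylmethyl arm and installing 2-(3-chlorophenyl)ethenyl. Nothing measured speaks to that change. For the measured compounds named here, with no relevant step and the one known step flat, no movement beyond the scatter is expected, and the step is expected to be a 1.2-fold lower number from compound 1 to compound 3 (0.06 log units; within the scatter). Compound 3 is estimated at 0.2 h, with a range from 0.08 h to 0.5 h.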

Compound 3, half-life: 0.352 h
Compound 3: the middle estimate sits 1.8-fold (0.25 log units) below what was measured, within the range that was stated.
By their numbers in this assay, from the lowest: compounds 2, 1 and 3 (each within the scatter of the next).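

In this assay the step of a 1.5-fold higher number from compound 1 to compound 3 (0.18 log units; within the scatter) stays within the scatter, so replacing the whole arm on this carbon of the five-membered aromatic ring with 2 nitrogen and 1 oxygen gives no readable change, whereas the earlier step altered only the end group on the triazole. The half-life therefore does not separate the arms, although (4-(1-hydroxy-1-methylethyl)-1H-1,2,3-triazol-1-yl)methyl carries 1 hydrogen-bond donor and 4 hydrogen-bond acceptors and 2-(3-chlorophenyl)ethenyl carries neither. No available measurement bears on why the number holds across this exchange.

Going by these compounds, it remains open whether any group at this position can move the half-life beyond the scatter. A primary amine or a carboxylic acid on the arm, or a bare methyl in its place, would put that question to the test.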